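The source may report more compounds than this note shows. Statements on the series, on what has been measured and on what is new or still open speak of the compounds shown alone.

Compound 1 `Cc1ccc(-c2cn(C[C@H]3c4c(ccc(O)c4C)[C@@H]4CC[C@@]5(C)C[C@]43CC5=O)nn2)cc1` gives > 20000 nM in a functional assay on SMMC-7721 cells (Homo sapiens) for cytotoxicity, read by MTT assay, with a stated time of 4 days (on this read-out lower numbers stand for stronger inhibition and higher numbers for weaker inhibition), a limit of the assay. Compound 2 `C=C1C(=O)[C@]23C[C@@]1(O)CC[C@H]2c1ccc(O)c(C)c1[C@@H]3Cn1cc(-c2ccc(OC)cc2)nn1` gives 860 nM in this assay. Compound 3 `Cc1ccc(-c2cn(C[C@H]3c4c(ccc(OS(=O)(=O)c5ccc(C)cc5)c4C)[C@@H]4CC[C@@]5(C)C[C@]43CC5=O)nn2)cc1` gives > 20000 nM in this assay, again a limit.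

Within the data shown here, compound 2 carries the only number among the three; the difference between its core and the core of compound 1 is not broken down here. From compound 1 to compound 3 the change is (4-methylphenyl)sulfonyl in place of hydrogen on an oxygen on an aromatic ring. That step, a step that the two limits leave unreadable from compound 1 to compound 3, cannot be read because the limit of > 20000 nM in this assay, at which 2 of the 3 values shown sit, holds both compounds. Compound 4 `C=C1C(=O)[C@]23C[C@@]1(O)CC[C@H]2c1ccc(OS(=O)(=O)c2ccc(C)cc2)c(C)c1[C@@H]3Cn1cc(-c2ccc(OC)cc2)nn1` is made from compound 2 by the same change, ((4-methylphenyl)sulfonyl in place of hydrogen on an oxygen on an aromatic ring). With the earlier step unreadable, the expectation for compound 4 rests only on compound 2 and its 860 nM. The step from compound 2 to compound 4 is estimated at a 2.3-fold higher number from compound 2 to compound 4 (0.37 log units; beyond the scatter). Compound 4 is expected to give 2000 nM in this assay, between 500 nM and 12000 nM.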

Compound 4, half-maximal inhibitory concentration: 1720 nM
For compound 4 the middle estimate is 1.2-fold (0.07 log units) above the measured one, within the range that was stated.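

In this assay, replacing hydroxy with ((4-methylphenyl)sulfonyl)oxy on the core of compound 2 gives a 2.0-fold higher number from compound 2 to compound 4 (0.30 log units; within the scatter), so on this core the change leaves the read-out within the usual scatter. The same change on the core of compound 1 cannot be read, and the two steps cannot be compared, because compound 1 and compound 3 both stand at a limit of the assay: the limit of > 20000 nM in this assay, at which 2 of the 4 values shown sit. The result therefore describes one core only and does not show that the change carries over from one core to another.

The compounds shown leave open what a smaller methylsulfonyl group on the same oxygen would give. They also leave open what an amine or a carboxylic acid in place of the hydroxy would give on the core of compound 2.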